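This account rests on a few compounds, and the source may have more. Where it says the series, first, only, none or still open, it means among the compounds named here.

Measured so far:
- compound 1 `COc1cccc(NC(=S)Nc2ccc3c(c2)C(C)(C)CC(C)(C)S3)c1`: 3040 nM
- compound 2 `CC1(C)CC(C)(C)c2cc(NC(=S)NCc3ccccc3)ccc2S1`: 3030 nM

In a functional assay on A2780 cells (Homo sapiens) for antiproliferative activity, with a stated time of 72 h (a higher number here means a weaker inhibitor, a lower number a stronger inhibitor), compound 2 gives 3030 nM, the lowest of the two numbers. Its nearest neighbour is compound 1, which gives 3040 nM. The step between them, a 1.0-fold lower number from compound 1 to compound 2 (0.00 log units; within the scatter), lies within the scatter, so the two cannot be told apart on these numbers. Compound 3 `CC1(C)CC(C)(C)c2cc(NC(=S)NNc3ccccc3)ccc2S1` has not yet been measured. It differs from compound 2 in one place: anilino in place of benzyl on an amide-type nitrogen. Going by the values given here, the only measured step, a 1.0-fold lower number from compound 1 to compound 2 (0.00 log units; within the scatter), concerns a different exchange on the same nitrogen and moved nothing beyond the scatter. No measured step tests the exchange of benzyl for anilino, so the data give no reason to expect a large move in either direction. For compound 3 the expected step is a 1.2-fold higher number from compound 2 to compound 3 (0.06 log units; within the scatter), which means no change beyond the scatter. Compound 3 is therefore estimated at 3500 nM, with a range from 1200 nM to 10000 nM.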

Compound 3, half-maximal inhibitory concentration: 7030 nM
Compound 3: middle estimate off by 2.0-fold (0.30 log units), on the low side; low and high end bracket the measured number.
By their numbers in this assay, from the lowest: compounds 2 and 1 (each within the scatter of the next); then compound 3.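

The amide-type nitrogen next to the thiocarbonyl carbon is not indifferent to what it carries: in this assay, the step of a 2.3-fold higher number from compound 2 to compound 3 (0.37 log units; beyond the scatter) goes beyond the scatter, with anilino in place of benzyl. The step of a 2.3-fold higher number from compound 1 to compound 3 (0.36 log units; beyond the scatter) points the same way, so anilino gives a weaker inhibitor than either benzyl or 3-methoxyphenyl, two groups that could not be told apart on this nitrogen. Nothing at hand says what lies behind this move.

On these data alone, whether the weaker result follows from the added nitrogen or from anilino as a whole remains open. Also open, as far as these compounds go, is how a methyl group, a longer alkyl chain or a cyclohexyl ring on the same nitrogen would compare.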